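A few compounds are considered here, and "the series" means these few. Any claim that something is new, unique, unknown or untested is made for them only; others in the source may bear on it.

Compound 1 `Cc1ccc(C2CNC(=O)N2S(=O)(=O)c2ccc(Cl)cc2)cc1`: 266000 nM
Compound 2 `Cc1ccc(C2CN(S(=O)(=O)c3ccccc3)C(=O)N2)cc1`: > 316000 nM
Compound 3 `Cc1ccc(S(=O)(=O)N2CC(c3ccc(Br)cc3)NC2=O)cc1`: > 253000 nM

All three measured compounds share one core and are weak in a functional assay on A549 cells (Homo sapiens) for cytotoxicity; a lower number here means a stronger inhibitor, a higher number a weaker inhibitor. Going by the values given here, compound 1 is the only one with a number in this assay, giving 266000 nM. For compound 2 this assay reports a limit, > 316000 nM, and not a number. For compound 3 it likewise reports a limit, > 253000 nM. Among the compounds with values here, compound 1 therefore stands as the sole numbered value, and it sits close to where the other two are cut off (the limit of > 253000 nM in this assay, at which 1 of the 3 values shown sits; (the limit of > 316000 nM in this assay, at which 1 of the 3 values shown sits)).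

Compound 4 `Cc1ccc(C2CNC(=O)N2S(=O)(=O)c2ccc(C)cc2)cc1` has not yet been measured. It differs from compound 1 in one place: methyl in place of chloro on an aromatic carbon. Within the data shown here, no step between measured compounds carries this change, so its size cannot be read from these data. Compound 3 also contains a 4-methylphenyl group and gives no number in this assay. For compound 4 a step of a 1.2-fold higher number from compound 1 to compound 4 (0.08 log units; within the scatter) is expected, toward weaker or no change beyond the scatter. Compound 4 is estimated at 320000 nM, within 150000 nM to 700000 nM, with a fair chance that this assay reports only a limit.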

Compound 4, half-maximal inhibitory concentration: > 302000 nM
Compound 4 ended at the assay's limit; the forecaster's own chance of this, stated with the estimate: 55%; the middle value lies beyond the limit too.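

In this assay, going by these compounds alone, the change from 4-chlorophenyl to 4-methylphenyl gives the first step that can be read at this position, an at least 1.1-fold higher number from compound 1 to compound 4 (0.05 log units; that floor lies within the scatter). Compound 4 carries a limit and not a number, so this step is only a floor, and it does not show that methyl and chloro differ here beyond the scatter: the limit of > 302000 nM in this assay, at which 1 of the 4 values shown sits. What it does show is that methyl in place of chloro on this aromatic carbon brings no strength that this assay can register, which leaves compound 4 without a number, like compound 2 and compound 3.

On these data alone, whether an amine or a carboxylic acid at this position would bring a number well under these values stays open. The compounds shown also leave open how far past its limit compound 4 lies.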